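Swapping a Methyl for a Hexyloxy Chain

The source may report more compounds than this note shows. Statements on the series, on what has been measured and on what is new or still open speak of the compounds shown alone.

Compound 3 `Cc1ccc(Cl)cc1COc1ccccc1C(=O)Nc1cccnc1` gives 1100 nM in an assay on lysate for inhibition of phosphatidylcholine:ceramide cholinephosphotransferase 2 (Homo sapiens), read by HPLC, with stated times of 30 min and 2 h (a lower number here means a stronger inhibitor, a higher number a weaker inhibitor), the lowest of the three numbers. Compound 1 `Cc1ccccc1COc1ccccc1C(=O)Nc1cccnc1` gives 1500 nM in this assay, and the step of a 1.4-fold lower number from compound 1 to compound 3 (0.13 log units; within the scatter) lies within the scatter. Compound 2 `N#Cc1ccccc1COc1ccccc1C(=O)Nc1cccnc1` gives 31800 nM in this assay, so the step of a 29-fold lower number from compound 2 to compound 3 (1.46 log units; beyond the scatter) is large. Compound 4 `CCCCCCOc1ccc(Cl)cc1COc1ccccc1C(=O)Nc1cccnc1` differs from compound 3 by hexyloxy in place of methyl on an aromatic carbon. Going by the values given here, the only measured change at that methyl is a 21-fold higher number from compound 1 to compound 2 (1.33 log units; beyond the scatter), a large increase, while a 1.4-fold lower number from compound 1 to compound 3 (0.13 log units; within the scatter) at another carbon was small; neither involves a hexyloxy, so they guide only loosely. The step of a 1.6-fold higher number from compound 3 to compound 4 (0.21 log units; within the scatter) is expected to be modest, in either direction. Compound 4 is therefore estimated at 1800 nM, with a range from 400 nM to 9000 nM.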

Compound 4, half-maximal inhibitory concentration: 520 nM
Estimate against measurement, compound 4: 3.5-fold (0.54 log units) above; low and high end bracket the measured number.
By their numbers in this assay, from the lowest: compound 4; then compounds 3 and 1 (each within the scatter of the next); then compound 2.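

In this assay the carbon that held the methyl accepts the much larger hexyloxy chain, with a 2.1-fold lower number from compound 3 to compound 4 (0.33 log units; beyond the scatter) as a modest gain in strength. The earlier change at this carbon, cyano in place of methyl, went the other way, with a 21-fold higher number from compound 1 to compound 2 (1.33 log units; beyond the scatter) as a large loss, so replacing this methyl does not always weaken the compound. No measurement here explains the difference. Going by these compounds, whether a shorter or longer chain would do better remains open, as does whether an amine at the end of the hexyloxy chain would keep the gain.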